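Benzofuran-thiazolyl ureas: nitro-to-bromo swap on the fused ring

The compounds below may be only part of what the source reports. "The series", "measured", "known", "first", "only" and "open" are said of these compounds alone.

Measured so far:
compound 1, `O=C(Nc1nc(-c2cc3cc(Br)ccc3o2)cs1)Nc1ccccc1[N+](=O)[O-]`, 166000 nM
compound 2, `O=C(Nc1ccccc1)Nc1nc(-c2cc3cc([N+](=O)[O-])ccc3o2)cs1`, 183000 nM

In a physicochemical assay, with a stated time of 6 min (on this read-out higher numbers stand for weaker inhibition and lower numbers for stronger inhibition), compound 1 gives 166000 nM and compound 2 gives 183000 nM. Compound 2 has the highest number of the two, but its nearest neighbour, compound 1, sits within the scatter, so no order between them can be read from these values. Both numbers stand at the weak end of this assay.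

Compound 3, `O=C(Nc1ccccc1)Nc1nc(-c2cc3cc(Br)ccc3o2)cs1`, is not yet measured. Its difference from compound 2 is bromo in place of nitro on an aromatic carbon. Going by the values given here, no step between measured compounds matches this change, so the size of its effect has no precedent here. The expectation is for compound 3 to stay close to compound 2, with a step of a 1.1-fold lower number from compound 2 to compound 3 (0.03 log units; within the scatter) that is estimated to fall within the scatter rather than beyond it. Compound 3 is thus expected at about 170000 nM, in a range from 80000 nM to 360000 nM.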

Compound 3, half-maximal inhibitory concentration: > 200000 nM
Compound 3 was reported as a limit; the forecaster's own chance of this, stated with the estimate: 20%; middle value at least 1.1-fold (0.07 log units) away from the limit.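

In this assay compound 3 is reported as a limit and not as a number, so the position gives a floor for this change and no measured size. Bromo in place of nitro on an aromatic carbon gives an at least 1.0-fold higher number from compound 2 to compound 3 (0.03 log units; that floor lies within the scatter), and the other single change, removal of a nitro group, gives an at least 1.2-fold higher number from compound 1 to compound 3 (0.08 log units; that floor lies within the scatter). Neither floor lies beyond the scatter, so neither step establishes a change, and the series now touches the end of the read-out: the limit of > 200000 nM in this assay, at which 1 of the 3 values shown sits.

Going by these compounds, how far the true value of compound 3 lies past its limit stays open, and with it the real size of both steps. Also open, on these data alone, is how an amine or a carboxylic acid at this position would read in this assay.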